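Arylidene semicarbazide series: replacing the dimethoxyphenyl with hydroxyphenyl

A few compounds are considered here, and "the series" means these few. Any claim that something is new, unique, unknown or untested is made for them only; others in the source may bear on it.

Compound 2 `COc1ccc(OC)c(/C=N/NC(=O)Nc2ccc(Oc3ccnc(-c4nncn4CCN(C)C)c3)c(F)c2)c1` gives 1510 nM in a functional assay on MKN-45 cells (Homo sapiens) for cytotoxicity, read by MTT assay, with a stated time of 72 h (on this read-out higher numbers stand for weaker inhibition and lower numbers for stronger inhibition), the second highest of the three numbers measured; compound 3 `CN(C)CCn1cnnc1-c1cc(Oc2ccc(NC(=O)N/N=C/c3c(O)ccc4ccccc34)cc2F)ccn1` gives 2020 nM, and compound 1 `CN(C)CCn1cnnc1-c1cc(Oc2ccc(NC(=O)N/N=C/c3c(Cl)cccc3Cl)cc2F)ccn1` gives 160 nM. Compound 4 `CN(C)CCn1cnnc1-c1cc(Oc2ccc(NC(=O)N/N=C/c3ccc(O)cc3)cc2F)ccn1` is not yet measured; (4-hydroxyphenyl in place of 2,5-dimethoxyphenyl on a carbon with a double bond to nitrogen). Among the compounds with values here, no measured step involves 4-hydroxyphenyl. Within the data shown here, the steps that bear on it indirectly are a 9.4-fold higher number from compound 1 to compound 2 (0.97 log units; beyond the scatter) and a 13-fold higher number from compound 1 to compound 3 (1.10 log units; beyond the scatter), both showing that leaving 2,6-dichlorophenyl weakens inhibition, while a 1.3-fold higher number from compound 2 to compound 3 (0.13 log units; within the scatter) shows two other aryl groups at this carbon give the same result within scatter. A step within scatter or modestly weaker is therefore expected, a 1.7-fold higher number from compound 2 to compound 4 (0.22 log units; within the scatter). Compound 4 is estimated at 2500 nM in this assay, with a range of 700 nM to 9000 nM.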

Compound 4, half-maximal inhibitory concentration: 820 nM
For compound 4 the middle estimate is 3.0-fold (0.48 log units) above the measured one, and the stated range covers the measured number.
By their numbers in this assay, from the lowest: compound 1; then compounds 4, 2 and 3 (each within the scatter of the next, the first and the last beyond it).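

In this assay, 4-hydroxyphenyl in place of 2,5-dimethoxyphenyl gives a 1.8-fold lower number from compound 2 to compound 4 (0.27 log units; within the scatter), so this change of aryl group on the carbon with a double bond to nitrogen leaves the result unchanged within scatter. The first separation among the groups other than 2,6-dichlorophenyl is a 2.5-fold lower number from compound 3 to compound 4 (0.39 log units; beyond the scatter). Compound 1 still holds the lowest number of the four, with a 5.1-fold higher number from compound 1 to compound 4 (0.71 log units; beyond the scatter).

Nothing shown explains these differences. Open, as far as these compounds go, is how 4-aminophenyl, 4-carboxyphenyl or a phenyl with a single chlorine would stand at this carbon against compound 1.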